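Three compounds at the limit, a fourth to come

This account rests on a few compounds, and the source may have more. Where it says the series, first, only, none or still open, it means among the compounds named here.

Compound 1 `Nc1[nH]c(C(=O)c2ccccc2)c(-c2ccc(Cl)cc2Cl)c1C(=O)c1ccc(Cl)cc1`, compound 2 `Nc1[nH]c(C(=O)c2ccccc2)c(-c2cccc3ccccc23)c1C(=O)c1ccc(Cl)c(Cl)c1` and compound 3 `Nc1[nH]c(C(=O)c2ccccc2)c(-c2ccc(Cl)cc2Cl)c1C(=O)c1cccs1` share one core and differ only in the groups attached to it. In an assay for inhibition of Polyunsaturated fatty acid lipoxygenase ALOX15 (Homo sapiens), with a stated time of 10 min (on this read-out lower numbers stand for stronger inhibition and higher numbers for weaker inhibition), compound 1 gives > 100000 nM, which is a limit of the assay rather than a number. In this assay compound 2 gives > 100000 nM, again a limit. In this assay compound 3 gives > 100000 nM, also a limit, so where compound 3 stands is known only as a bound and not as a value. Within the data shown here, the single measured step between close neighbours, a step that the two limits leave unreadable from compound 1 to compound 3, cannot be read in size because of the limit of > 100000 nM in this assay, at which 3 of the 3 values shown sit. Compound 4 `Nc1[nH]c(C(=O)c2ccccc2)c(-c2ccc(Cl)cc2Cl)c1C(=O)c1ccc(Cl)c(Cl)c1` arises from compound 3 by 3,4-dichlorophenyl in place of thiophen-2-yl on a carbonyl carbon. Among the measured compounds shown here, no measured step with a readable size bears on this change, and the one related step is unreadable, so in this assay no movement beyond the scatter is expected in either direction. The step expected in this assay is a step that the limit leaves unreadable from compound 3 to compound 4. Compound 4 is expected at 200000 nM, with a range from 60000 nM to 1000000 nM.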

Compound 4, half-maximal inhibitory concentration: 12800 nM
Beside the measured number, compound 4's estimate is 16-fold (1.19 log units) above it, outside the stated range (below it).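

In this assay compound 4 is the only compound shown with a number rather than a limit, and 3,4-dichlorophenyl in place of thiophen-2-yl on a carbonyl carbon gives an at least 7.8-fold lower number from compound 3 to compound 4 (0.89 log units; beyond the scatter). A single chloro in place of hydrogen on an aromatic carbon gives an at least 7.8-fold lower number from compound 1 to compound 4 (0.89 log units; beyond the scatter), while 2,4-dichlorophenyl in place of naphthalen-1-yl on an aromatic carbon gives an at least 7.8-fold lower number from compound 2 to compound 4 (0.89 log units; beyond the scatter), so a change at either of these two places can separate a compound with a number from one at the limit. Each of these sizes is only a minimum, because the other end of every step is a limit of the assay and not a number: the limit of > 100000 nM in this assay, at which 3 of the 4 values shown sit.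

With one number in hand, nothing yet ranks groups against each other at either place. From the compounds shown here alone, what an amine or a carboxylic acid on the 3,4-dichlorophenyl ring, or a longer chain in its stead, would do remains open.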